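This account rests on a few compounds, and the source may have more. Where it says the series, first, only, none or still open, it means among the compounds named here.

Measured so far:
- compound 1, `CN1CC[C@H](N(C)C(=O)N2CC[C@H](n3cnc4cc(-c5ccc6c(c5)OCCO6)sc4c3=O)C2)C1`, with 143 nM in an assay on isolated protein for binding affinity to melanin-concentrating hormone receptor 1 (Homo sapiens); on this read-out lower numbers stand for stronger inhibition and higher numbers for weaker inhibition
- compound 2, `CN(C(=O)N1CC[C@H](n2cnc3cc(-c4ccc(OC(F)(F)F)cc4)sc3c2=O)C1)[C@H]1CCN(C2CCOCC2)C1`, with 18 nM in this assay

Compound 2 gives the lower of the two numbers, and its gap to compound 1 lies beyond the scatter; the two compounds differ in more than one place, so the gap cannot be tied to a single change.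

Compound 3, `CN(C(=O)N1CC[C@H](n2cnc3cc(-c4ccc5c(c4)OCCO5)sc3c2=O)C1)[C@H]1CCN(C2CCOCC2)C1`, has not been measured. It differs from compound 2 in one place: 2,3-dihydro-1,4-benzodioxin-6-yl in place of 4-(trifluoromethoxy)phenyl on an aromatic carbon. Going by the values given here, the same 2,3-dihydro-1,4-benzodioxin-6-yl group sits in compound 1, whose number is the higher of the two; the other part of compound 1 differs as well, so no clean step is available.

Compound 3 is expected to give a number in this assay of about 40 nM, between 12 nM and 130 nM. This estimate means a step of a 2.2-fold higher number from compound 2 to compound 3 (0.35 log units; beyond the scatter), a modest weakening that may not exceed the scatter.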

Compound 3, inhibition constant: 45 nM
Beside the measured number, compound 3's estimate is 1.1-fold (0.05 log units) below it, within the range that was stated.
By their numbers in this assay, from the lowest: compound 2; then compound 3; then compound 1.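

In this assay, the group on the aromatic carbon next to the ring sulfur can now be read on its own: 2,3-dihydro-1,4-benzodioxin-6-yl in place of 4-(trifluoromethoxy)phenyl gives a 2.5-fold higher number from compound 2 to compound 3 (0.40 log units; beyond the scatter) and so costs some binding strength without losing it. The other difference between compound 1 and compound 2 can also be read separately, as oxan-4-yl in place of methyl on an amine nitrogen in a ring gives a 3.2-fold lower number from compound 1 to compound 3 (0.50 log units; beyond the scatter) and so improves the number. Nothing measured here explains either step.

Going by these compounds, how a plain phenyl or a pyridine ring would behave on that aromatic carbon remains open. On the amine nitrogen, only methyl and oxan-4-yl appear, so the effect of a cyclopentyl or an acetyl group is also unknown.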